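Methoxy in Place of Methylamino on a Nucleoside Core

A few compounds are considered here, and "the series" means these few. Any claim that something is new, unique, unknown or untested is made for them only; others in the source may bear on it.

Measured compounds:
compound 1, `COc1ncnc2c1c(-c1ccoc1)cn2[C@@H]1O[C@H](CO)[C@@H](O)[C@H]1O`, 1790 nM
compound 2, `C#Cc1cn([C@@H]2O[C@H](CO)[C@@H](O)[C@H]2O)c2ncnc(NC)c12`, reported only as a limit, > 20000 nM

Both compounds were tested in a functional assay on HeLa S3 cells (Homo sapiens) for antiproliferative activity, read by XTT assay, with a stated time of 72 h; on this read-out higher numbers stand for weaker inhibition and lower numbers for stronger inhibition. Compound 1 gives 1790 nM. For compound 2 this assay reports no number but only a limit, > 20000 nM. For the measured compounds named here, that is the limit of > 20000 nM in this assay, at which 1 of the 2 values shown sits, so compound 2 stands at the limit of the two values shown, while compound 1 is the one with a measured number.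

Compound 3, `C#Cc1cn([C@@H]2O[C@H](CO)[C@@H](O)[C@H]2O)c2ncnc(OC)c12`, is not yet measured. It differs from compound 2 in one place: methoxy in place of methylamino on an aromatic carbon. Going by the values given here, no measured pair shows this change on its own, so its size is not known from the data. Compound 1 carries a methoxy group and gives a number, whereas compound 2 carries methylamino and sits at the limit, but these two compounds also differ elsewhere, so they do not isolate the change.

Going from compound 2 to compound 3, a step toward stronger inhibition of about an at least 2.0-fold lower number from compound 2 to compound 3 (0.30 log units; that floor lies within the scatter) is expected. Compound 3 is therefore estimated at 10000 nM, expected to lie between 2000 nM and 40000 nM.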

Compound 3, half-maximal inhibitory concentration: 1730 nM
Beside the measured number, compound 3's estimate is 5.8-fold (0.76 log units) above it, and the stated range ends above it.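

In this assay, the exchange of methylamino for methoxy on this aromatic carbon, with the rest of the molecule unchanged, now appears on its own and gives an at least 11-fold lower number from compound 2 to compound 3 (1.06 log units; beyond the scatter), so this one position can decide whether the compound shows a measurable number at all. Compound 2 is reported only as a limit, so this step is a floor and its full size stays unknown: the limit of > 20000 nM in this assay, at which 1 of the 3 values shown sits.

With methoxy in place, the group on the other aromatic carbon makes no visible difference, since ethynyl in place of furan-3-yl gives a 1.0-fold lower number from compound 1 to compound 3 (0.01 log units; within the scatter), and so the two compounds carrying methoxy cannot be told apart here.

The compounds shown do not settle whether the result depends on methoxy itself or only on the loss of methylamino and its hydrogen-bond donor, and a plain amine, an ethoxy group or a chlorine atom at this position would help to separate these. On these data alone, how furan-3-yl behaves alongside methylamino also stays open, as does whether ethynyl and furan-3-yl would still match with any group other than methoxy.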